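A few compounds are considered here, and "the series" means these few. Any claim that something is new, unique, unknown or untested is made for them only; others in the source may bear on it.

Series notes. Compound 1 `COc1ccc2c(c1)c(CC(=O)NS(=O)(=O)c1ccc(Cl)c([N+](=O)[O-])c1)c(C)n2-c1ccc(C)cc1` is tested in an assay on isolated protein for binding affinity to Apoptosis regulator Bcl-2 (Homo sapiens), read by fluorescence polarization, with stated times of 30 min and 20 min; a lower number here means a stronger inhibitor, a higher number a weaker inhibitor; in this assay compound 1 gives only a limit, > 10000 nM. Compound 2 `COc1ccc(S(=O)(=O)NC(=O)Cc2c(C)n(-c3ccc(C)cc3)c3ccc(OC)cc23)cc1` likewise stops at a limit in this assay, > 10000 nM. Compound 3 `COc1ccc2c(c1)c(CC(=O)NS(=O)(=O)c1ccc(N3CCN(C)CC3)c([N+](=O)[O-])c1)c(C)n2-c1ccc(C)cc1` also returns only a limit in this assay, > 10000 nM. The two steps measured so far, a step that the two limits leave unreadable from compound 1 to compound 2 and a step that the two limits leave unreadable from compound 1 to compound 3, cannot be sized, since (the limit of > 10000 nM in this assay, at which 3 of the 3 values shown sit). Compound 4 `COc1ccc(S(=O)(=O)NC(=O)Cc2c(C)n(-c3ccc(-c4ccccc4)cc3)c3ccc(OC)cc23)cc1` differs from compound 2 by phenyl in place of methyl on an aromatic carbon. Among the compounds with values here, no measured step bears on this change, and no step in this assay is readable at all, so compound 4 is expected to remain near the same limit, an estimated step that the limit leaves unreadable from compound 2 to compound 4. The expected value for compound 4 is 15000 nM, within 3000 nM to 60000 nM.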

Compound 4, inhibition constant: > 10000 nM
Compound 4 gave a limit, no number; the forecaster's own chance of this, stated with the estimate: 75%; the middle value is on the limit's open side.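

No new step can be read between compound 2 and compound 4, since both stop at a limit: the limit of > 10000 nM in this assay, at which 4 of the 4 values shown sit.

The compounds shown leave open whether any change to the shared core gives a measurable inhibition constant in this assay.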